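Fixing One Undrawn Centre in a Pepsin Inhibitor

The compounds below may be only part of what the source reports. "The series", "measured", "known", "first", "only" and "open" are said of these compounds alone.

Compound 1 `CC(C)CCNC(=O)C(C)NC(=O)C(Cc1ccccc1)C[C@H](O)[C@H](CC(C)C)NC(=O)C(NC(=O)CC(C)C)C(C)C` is tested in an assay on isolated protein for inhibition of Pepsin A (Sus scrofa) (a higher number here means a weaker inhibitor, a lower number a stronger inhibitor), where compound 1 gives 2.5 nM. Two companions share much of its chain but differ in the middle section: compound 2 `CC(C)CCNC(=O)C(C)NC(=O)CCC(=O)[C@H](CC(C)C)NC(=O)C(NC(=O)CC(C)C)C(C)C` gives 2140 nM in this assay, and compound 3 `CC(C)CCNC(=O)C(C)NC(=O)CC(=O)C(CC(C)C)NC(=O)C(NC(=O)CC(C)C)C(C)C` gives 56 nM. Compound 1 therefore carries the lowest number of the three; compound 3 comes closest, yet its gap to compound 1 lies beyond the scatter, and compound 2 sits furthest away, also beyond the scatter.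

Compound 4 `CC(C)CCNC(=O)C(C)NC(=O)[C@H](Cc1ccccc1)C[C@H](O)[C@H](CC(C)C)NC(=O)C(NC(=O)CC(C)C)C(C)C` differs from compound 1 only in how one centre is drawn: the two compounds have the same atoms and bonds; at least one stereo element is drawn with a configuration in one of them and without one in the other: 1 of 5 stereo elements differ; a stereocentre at a saturated chain carbon is drawn without a configuration in compound 1 and R in compound 4. For the measured compounds named here, no step between two measured compounds mirrors this change, so the expectation rests on the fact that compound 1 may stand for more than one arrangement at that centre while compound 4 fixes a single one. A small move toward a lower number, or none beyond the scatter, is expected. Compound 4 is estimated at 1.5 nM, with a range from 0.5 nM to 6 nM. The expected step is a 1.7-fold lower number from compound 1 to compound 4 (0.22 log units; within the scatter).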

Compound 4, inhibition constant: 140 nM
Compound 4: middle estimate off by 93-fold (1.97 log units), on the low side; measured number outside the range, above it.
By their numbers in this assay, from the lowest: compound 1; then compound 3; then compound 4; then compound 2.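

For the compounds shown here, with no atom or bond changed, the numbers in this assay still part by a large step (a 56-fold higher number from compound 1 to compound 4 (1.75 log units; beyond the scatter)), so this single centre carries a weight that the earlier compounds, which differ in their middle section, could not reveal. The R arrangement alone does not reproduce the number of compound 1. If compound 1 holds more than one arrangement at this centre, its low number would have to come mainly from another arrangement, an inference that rests only on this difference in drawing: the fact that one of compounds 1 and 4 is drawn with a defined configuration and the other without, at the place where they differ

Which arrangements compound 1 actually contains stays open, as does the number for the S arrangement on its own. Also open, from the compounds shown here alone, is how a longer chain or an amine on this same carbon would behave in either arrangement.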